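The source may report more compounds than this note shows. Statements on the series, on what has been measured and on what is new or still open speak of the compounds shown alone.

Measured so far:
compound 1 `O=C1N/C(=N/c2ccccc2)S/C1=C\c1ccccn1`: 26.2%
compound 2 `O=C1N/C(=N/c2ccc(Cl)cc2)S/C1=C\c1ccccn1`: 34.8%

In a functional assay on the whole organism (strain Wistar) for inhibition, with Rattus norvegicus as the target, read by paw edema, with stated times of 30 min and 120 min, at a dose of 10 mg/kg by the oral route (on this read-out lower numbers stand for less inhibition and higher numbers for more inhibition at the one dose given (going by the name of the read-out)), compound 2 gives 34.8%, the higher of the two numbers shown, with compound 1 nearest at 26.2%; the step of a number 8.6 percentage points higher from compound 1 to compound 2 (within the scatter) lies within the scatter, so the two cannot be ranked on these numbers. Compound 3 `Cc1cccc(/N=C2/NC(=O)/C(=C/c3ccccn3)S2)c1` differs from compound 2 in one place: 3-methylphenyl in place of 4-chlorophenyl on a double-bonded nitrogen. Among the measured compounds shown here, no measured step covers this change. For the measured compounds named here, the only step available, a number 8.6 percentage points higher from compound 1 to compound 2 (within the scatter), concerns chloro in place of hydrogen on an aromatic carbon and was itself within the scatter, so it gives no guide to the size or direction of the present change. Nothing in the series therefore points to a step beyond the scatter in this assay, in either direction. Compound 3 is expected to give 31%, in the range 16% to 46%. The step this estimate means, a number 3.8 percentage points lower from compound 2 to compound 3 (within the scatter), is expected to stay within the scatter.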

Compound 3, a percentage reported as inhibition, in the whole organism at one dose (the size of the read-out at that dose, not a potency): 39.7%
The estimate for compound 3 lay 8.7 percentage points below the measured number; low and high end bracket the measured number.
By their numbers in this assay, from the lowest: compounds 1, 2 and 3 (each within the scatter of the next, the first and the last beyond it).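

Methyl in place of hydrogen on the aromatic ring gives the first step in the series that can be read in this assay: a number 13.5 percentage points higher from compound 1 to compound 3 (beyond the scatter). The chloro step did not show this, so a substituent on this ring, attached through the double-bonded nitrogen, can now be said to shift the read-out at the one dose given, if modestly. By contrast, 3-methylphenyl in place of 4-chlorophenyl gives a number 4.9 percentage points higher from compound 2 to compound 3 (within the scatter), so these two groups cannot be told apart, and no measured property of either group bears on the result.

From the compounds shown here alone, it remains open how 4-methylphenyl or 3-chlorophenyl would compare with 3-methylphenyl, which would separate the group from its place on the ring. Also open, going by these compounds, is whether an amine, a carboxylic acid or a longer alkyl chain on this ring would give a larger step.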